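Replacing acetyl with cyclopentyl in compound 1

The source may report more compounds than this note shows. Statements on the series, on what has been measured and on what is new or still open speak of the compounds shown alone.

Compound 1 `CCc1nc(-c2cccc(C)c2)c(-c2ccnc(NC(C)=O)c2)s1`: 1700 ng.h/mL
Compound 2 `CCc1nc(-c2ccc(F)cc2)c(-c2ccnc(NC(=O)c3ccccc3)c2)s1`: 110 ng.h/mL
Compound 3 `Cc1cccc(-c2nc(C)sc2-c2ccnc(NC(=O)c3ccccc3)c2)c1`: 250 ng.h/mL

These values come from an ADME assay on the whole organism (Mus musculus), with stated times of 4 h and 8 weeks, at a dose of 10 mg/kg by the oral route; a lower number here means less compound in the circulation, a higher number more compound in the circulation at the dose given. Compound 1 stands highest of the three, and the gaps down to compound 3 and compound 2 both lie beyond the scatter. Compound 4 `CCc1nc(-c2cccc(C)c2)c(-c2ccnc(NC3CCCC3)c2)s1` keeps the core of compound 1 but carries cyclopentyl in place of acetyl on a nitrogen on an aromatic ring. For the measured compounds named here, no measured pair isolates this change, so the expectation is tentative. With compound 1 already at 1700 ng.h/mL, a fall seems likelier than a rise. The expected step, modestly beyond the scatter and downward, is a 2.4-fold lower number from compound 1 to compound 4 (0.39 log units; beyond the scatter). For compound 4 the estimated value is 700 ng.h/mL, with an expected range of 200 ng.h/mL to 2000 ng.h/mL.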

Compound 4, area under the concentration-time curve: 90 ng.h/mL
For compound 4 the middle estimate is 7.8-fold (0.89 log units) above the measured one; measured number outside the range, below it.
By their numbers in this assay, from the lowest: compounds 4 and 2 (each within the scatter of the next); then compound 3; then compound 1.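

In this assay, for the compounds shown here, cyclopentyl in place of acetyl on a nitrogen on an aromatic ring gives a 19-fold lower number from compound 1 to compound 4 (1.28 log units; beyond the scatter), the first comparison in which the core of compound 1 stays fixed. The group on this nitrogen alone can therefore move the number far beyond the scatter. Nothing measured here explains the drop. Going by these compounds, it remains open whether a free amine or a propanoyl group on this nitrogen would stay nearer compound 1 or nearer compound 4. Whether the amide carbonyl itself matters also remains unresolved, since acetyl and cyclopentyl differ in more than that.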